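Aryl amide change from compound 3 to compound 4

A few compounds are considered here, and "the series" means these few. Any claim that something is new, unique, unknown or untested is made for them only; others in the source may bear on it.

In a functional assay on C8166 cells (Homo sapiens) for cytotoxicity, read by MTT assay (a lower number here means that less compound is tolerated, a higher number that more compound is tolerated), compound 1 (`Cc1cccc(C(=O)Nc2cc(Cl)ccc2OCC(=O)Nc2ccc(S(N)(=O)=O)cc2C)c1`) gives 52900 nM, compound 2 (`Cc1cc(S(N)(=O)=O)ccc1NC(=O)COc1ccc(Cl)cc1NC(=O)c1cccc(F)c1`) gives 243000 nM and compound 3 (`COc1ccc(C(=O)Nc2cc(Cl)ccc2OCC(=O)Nc2ccc(S(N)(=O)=O)cc2C)cc1`) gives 69500 nM. Compound 3 is not separated from compound 1, with a 1.3-fold higher number from compound 1 to compound 3 (0.12 log units; within the scatter), and compound 2 stands apart, with a 4.6-fold higher number from compound 1 to compound 2 (0.66 log units; beyond the scatter) and a 3.5-fold lower number from compound 2 to compound 3 (0.54 log units; beyond the scatter). Compound 4 (`Cc1cc(S(N)(=O)=O)ccc1NC(=O)COc1ccc(Cl)cc1NC(=O)c1ccc(Cl)cc1Cl`) carries 2,4-dichlorophenyl in place of 4-methoxyphenyl on a carbonyl carbon. Going by the values given here, all three measured steps change the aromatic group at this place, so they bear on it, but none of the measured compounds has the entering group. No step beyond the scatter is expected, and the estimated change is a 1.1-fold lower number from compound 3 to compound 4 (0.03 log units; within the scatter). The range stays wide and reaches the level of compound 2. For compound 4 the expected value is 65000 nM, with an estimated range of 25000 nM to 180000 nM.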

Compound 4, half-maximal cytotoxic concentration: 61100 nM
Beside the measured number, compound 4's estimate is 1.1-fold (0.03 log units) above it, and the stated range covers the measured number.
By their numbers in this assay, from the lowest: compounds 1, 4 and 3 (each within the scatter of the next); then compound 2.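

In this assay, 2,4-dichlorophenyl on the carbonyl carbon cannot be told apart from 4-methoxyphenyl (a 1.1-fold lower number from compound 3 to compound 4 (0.06 log units; within the scatter)) or from 3-methylphenyl (a 1.2-fold higher number from compound 1 to compound 4 (0.06 log units; within the scatter)). Only 3-fluorophenyl stands apart (a 4.0-fold lower number from compound 2 to compound 4 (0.60 log units; beyond the scatter)), so compounds 1, 3 and 4 now form one group, with compound 2 as the single exception among the four. No measured evidence accounts for this separation.

Open, as far as these compounds go, is whether an unsubstituted phenyl on this carbonyl carbon would read with compound 2 or with the other three. Also open, from the compounds shown here alone, is how an aryl group carrying an amine or a carboxylic acid would read.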